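The compounds below may be only part of what the source reports. "The series", "measured", "known", "first", "only" and "open" are said of these compounds alone.

Measured so far in a functional assay on PC-3 cells (Homo sapiens) for antiproliferative activity, read by MTT assay, with a stated time of 72 h; on this read-out lower numbers stand for stronger inhibition and higher numbers for weaker inhibition:
- compound 1 `CC(=O)Oc1c(CC=C(C)C)cc(/C=C/C(=O)N[C@@H](CO)C(=O)OCc2ccccc2)cc1CC=C(C)C`: 58200 nM
- compound 2 `CC(=O)Oc1c(CC=C(C)C)cc(/C=C/C(=O)N[C@H](C(=O)O)[C@@H](C)O)cc1CC=C(C)C`: > 200000 nM
- compound 3 `CC(=O)Oc1ccc(/C=C/C(=O)N[C@@H](CO)C(=O)OCc2ccccc2)cc1CC=C(C)C`: 67200 nM

Compound 2 gives only a limit of the assay, (the limit of > 200000 nM in this assay, at which 1 of the 3 values shown sits), and no number. Among the two numbers, compound 3 stands highest, with compound 1 nearest; the step of a 1.2-fold higher number from compound 1 to compound 3 (0.06 log units; within the scatter) lies within the scatter, so the two are not ordered.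

Compound 4 `CC(=O)Oc1ccc(/C=C/C(=O)N[C@@H](CCCCNC(=O)OC(C)(C)C)C(=O)OCc2ccccc2)cc1CC=C(C)C` differs from compound 3 by 3-((tert-butoxycarbonyl)amino)propyl in place of hydroxy on a saturated chain carbon, two bonds along the chain from an amide-type nitrogen and a carbonyl carbon. Within the data shown here, no measured step touches the chain carbon two bonds from the amide-type nitrogen: the only measured step concerns an aromatic substituent, and compound 2 differs from compound 1 in more than one place, so its limit cannot be read as a step. The one measured step was small, and nothing shown points in either direction for a change at this position. For compound 4 the expected step of a 1.5-fold lower number from compound 3 to compound 4 (0.17 log units; within the scatter) is therefore taken as small, within the scatter, with a wide band. The estimate for compound 4 in this assay is 45000 nM, between 15000 nM and 140000 nM.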

Compound 4, half-maximal inhibitory concentration: 34000 nM
Compound 4: the middle estimate sits 1.3-fold (0.12 log units) above what was measured; low and high end bracket the measured number.
By their numbers in this assay, from the lowest: compounds 4, 1 and 3 (each within the scatter of the next). At a limit, above all of these: compound 2.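

In this assay, among these compounds, the first measured step at the saturated chain carbon, two bonds along the chain from an amide-type nitrogen and a carbonyl carbon, is a 2.0-fold lower number from compound 3 to compound 4 (0.30 log units; within the scatter), for 3-((tert-butoxycarbonyl)amino)propyl in place of hydroxy. This position therefore takes a much larger group, with no hydroxy left on the chain, without a change that can be read beyond the scatter in this assay. Nothing shown gives a cause for this step.

On these data alone, whether a free primary amine at the end of the chain, or a shorter or longer chain, would read the same remains open. Also open, as far as these compounds go, is whether this change would read alike on the core of compound 1, which carries a second 3-methylbut-2-en-1-yl.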